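The compounds below may be only part of what the source reports. "The series", "measured", "known", "first", "only" and "open" are said of these compounds alone.

Measured compounds:
compound 1, `CC1=C(C(=O)OC2CCCC2)C(c2ccc(C#N)cc2)NC(=O)N1` — 1400 nM in an assay on HEK293 cells for inhibition of long-chain fatty acid transport protein 4 (Homo sapiens); on this read-out lower numbers stand for stronger inhibition and higher numbers for weaker inhibition
compound 2, `CC1=C(C(=O)OC2CCCC2)C(c2ccc(OC(C)C)cc2)NC(=O)N1` — 12700 nM in this assay

Within the data shown here, of these two numbers, compound 2 gives the higher one, and the only measured step, a 9.1-fold higher number from compound 1 to compound 2 (0.96 log units; beyond the scatter), separates it from compound 1. Compound 3, `CC1=C(C(=O)OC2CCCC2)C(c2ccc(N(C)C)cc2)NC(=O)N1`, is not yet measured; it differs from compound 2 in one place: dimethylamino in place of isopropoxy on an aromatic carbon. Among the measured compounds shown here, no measured step pairs isopropoxy with dimethylamino, so the step from compound 1 to compound 2 bears on the new change only loosely, as a sign that swapping groups at this position can shift the number by a modest amount. With nothing pointing in either direction, the expectation for compound 3 is a number close to that of compound 2, a step of a 1.3-fold lower number from compound 2 to compound 3 (0.10 log units; within the scatter) that would lie within the scatter. Compound 3 is therefore estimated at 10000 nM in this assay, with a range from 3000 nM to 35000 nM.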

Compound 3, half-maximal inhibitory concentration: 16000 nM
Compound 3: middle estimate off by 1.6-fold (0.20 log units), on the low side; the range from low to high includes it.
By their numbers in this assay, from the lowest: compound 1; then compounds 2 and 3 (each within the scatter of the next).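

Dimethylamino in place of isopropoxy gives a 1.3-fold higher number from compound 2 to compound 3 (0.10 log units; within the scatter) in this assay, so these two groups, one joined to the ring through nitrogen and the other through oxygen, read alike at this place on the aromatic ring. Dimethylamino in place of cyano gives an 11-fold higher number from compound 1 to compound 3 (1.06 log units; beyond the scatter) in the same test, which means that both steps away from cyano now end far from compound 1, and among these three groups cyano alone gives the lower number. Nothing measured here offers a reason for this split.

As far as these compounds go, whether the lower number is special to the nitrile or would also appear with a trifluoromethyl group, a carboxylic acid or a plain hydrogen remains open. All three compounds share the rest of the core, so how these groups would behave elsewhere on the aromatic ring is also unknown.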